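Swapping the Indole Group for a Dichlorophenylamino Group

The source may report more compounds than this note shows. Statements on the series, on what has been measured and on what is new or still open speak of the compounds shown alone.

In a functional assay on A549 cells (Homo sapiens) for inhibition, with a stated time of 72 h (a lower number here means a stronger inhibitor of growth, a higher number a weaker inhibitor of growth), compound 1 `O=C(c1cc(-n2ccc3ccccc32)c(O)cc1O)N1Cc2ccccc2C1` gives 14300 nM. Within the data shown here, only one other number is available for comparison: compound 2 `Cc1ccc2c(ccn2-c2cc(C(=O)N3Cc4ccccc4C3)c(O)cc2O)c1` gives 11100 nM, which lies within the usual scatter of compound 1. Compound 3 `O=C(c1cc(Nc2ccc(Cl)cc2Cl)c(O)cc1O)N1Cc2ccccc2C1` has not yet been measured. It keeps the core of compound 1 but changes one group on an aromatic carbon: (2,4-dichlorophenyl)amino in place of 1H-indol-1-yl on an aromatic carbon. The (2,4-dichlorophenyl)amino group therefore replaces the 1H-indol-1-yl group entirely.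

Among the measured compounds shown here, only one measured step offers any guidance. Placing a methyl in place of hydrogen on an aromatic carbon gives a 1.3-fold lower number from compound 1 to compound 2 (0.11 log units; within the scatter). That is a small edit on the indole-bearing compounds, so it says little about exchanging the whole group. For the measured compounds named here, no measured compound shows this exchange, so the data favour neither direction, and no shift beyond the scatter is expected. The estimated change is a 1.4-fold lower number from compound 1 to compound 3 (0.16 log units; within the scatter), with wide uncertainty. For compound 3, the expected value is about 10000 nM, within an estimated range of 3000 nM to 30000 nM.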

Compound 3, concentration for 50% growth inhibition: 24200 nM
Estimate against measurement, compound 3: 2.4-fold (0.38 log units) below; low and high end bracket the measured number.
By their numbers in this assay, from the lowest: compounds 2, 1 and 3 (each within the scatter of the next, the first and the last beyond it).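

In this assay, exchanging the whole 1H-indol-1-yl group for (2,4-dichlorophenyl)amino gives a 1.7-fold higher number from compound 1 to compound 3 (0.23 log units; within the scatter) and so leaves the two numbers impossible to tell apart. The earlier methyl step was only a small edit on the indole, whereas this exchange removes the five-membered aromatic ring, brings in two chlorine atoms and adds a hydrogen-bond donor, so this position, ortho to a hydroxy group, tolerates a far larger change of structure than the first two compounds could show. No measurement of any property or mechanism bears on this result, so nothing can be said about why the two groups read alike.

From the compounds shown here alone, it remains open what a plain phenylamino group, carrying neither chlorine, would give, and so whether the chlorine atoms play any part here. Also open, going by these compounds, is whether a very different group at this position, such as a simple dimethylamino group or a carboxylic acid, would move the number beyond the scatter in either direction.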